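Methoxy in place of trifluoromethyl: compound 3 to compound 4

A few compounds are considered here, and "the series" means these few. Any claim that something is new, unique, unknown or untested is made for them only; others in the source may bear on it.

Compound 1 `Cc1cc(NC(=O)Nc2cccc([N+](=O)[O-])c2)c2ccccc2n1`: > 25000 nM (a limit)
Compound 2 `COC(=O)c1cccc(NC(=O)Nc2cc(C)nc3ccccc23)c1`: 21000 nM
Compound 3 `Cc1cc(NC(=O)Nc2cccc(C(F)(F)F)c2)c2ccccc2n1`: > 25000 nM (a limit)

These compounds were tested in an ADME assay on BJ cells (Homo sapiens) for cytotoxicity, with a stated time of 72 h; a lower number here means that less compound is needed, a higher number that more compound is needed for the effect. Compound 3 gives only a limit, > 25000 nM, not an exact number. Compound 1 also gives only a limit, > 25000 nM. Compound 2 alone has a number, 21000 nM. The picture so far is therefore dominated by the limit of > 25000 nM in this assay, at which 2 of the 3 values shown sit.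

Compound 4 `COc1cccc(NC(=O)Nc2cc(C)nc3ccccc23)c1` has not yet been measured. It carries methoxy in place of trifluoromethyl on an aromatic carbon.

Three measured steps exchange a group on an aromatic carbon: an at least 1.1-fold lower number from compound 1 to compound 2 (0.07 log units; that floor lies within the scatter), an at least 1.1-fold higher number from compound 2 to compound 3 (0.07 log units; that floor lies within the scatter) and a step that the two limits leave unreadable from compound 1 to compound 3. None of them can be read as a step beyond the scatter, so none beyond the scatter is expected here in this assay. The expected change is an at least 1.0-fold lower number from compound 3 to compound 4 (0.01 log units; that floor lies within the scatter). Compound 4 is estimated at 24000 nM, with an expected range of 14000 nM to 35000 nM, and the assay may well report only a limit.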

Compound 4, half-maximal effective concentration: 27000 nM
For compound 4 the middle estimate is 1.1-fold (0.05 log units) below the measured one; low and high end bracket the measured number.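

Exchanging methoxycarbonyl for methoxy on this aromatic carbon gives a 1.3-fold higher number from compound 2 to compound 4 (0.11 log units; within the scatter) in this assay. Among the compounds shown here, compound 4 therefore provides a second exact number for this position, and the one readable step between two exact numbers shows no separation between these two groups. The steps to compound 4 from compound 1 and from compound 3 cannot be read, because each of those two compounds gives only a limit: the limit of > 25000 nM in this assay, at which 2 of the 4 values shown sit.

From the compounds shown here alone, it remains open whether any group on this aromatic carbon can produce a step beyond the scatter, for instance an amine, a carboxylic acid or a longer chain. The compounds shown also leave open whether a change elsewhere on the shared core would move the number in this assay more clearly than these exchanges do.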